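This account rests on a few compounds, and the source may have more. Where it says the series, first, only, none or still open, it means among the compounds named here.

Measured so far in this assay:
compound 1 `O=C(/C=C/c1ccc(C(F)(F)F)cc1)c1cccc(O)c1` — > 10000 nM
compound 2 `O=C(/C=C/c1ccc(C(F)(F)F)cc1)c1ccc(O)cc1` — > 10000 nM
compound 3 `O=C(/C=C/c1ccccc1OC(F)(F)F)c1cccc(O)c1` — 1610 nM

In a functional assay on RAW264.7 cells (Mus musculus) for inhibition, read by fluorescence, with stated times of 1 h, 24 h and 30 min (a lower number here means a stronger inhibitor, a higher number a weaker inhibitor), compound 1 gives > 10000 nM, which is a limit of the assay and not a number. Compound 2 likewise gives > 10000 nM, again only a limit. Among the compounds with values here, compound 3 gives 1610 nM, the only actual number in the set. The change 4-hydroxyphenyl in place of 3-hydroxyphenyl on a carbonyl carbon gives the step that the two limits leave unreadable from compound 1 to compound 2, unreadable because of the limit of > 10000 nM in this assay, at which 2 of the 3 values shown sit. How the core of compound 3 differs from that of compound 1 is not broken down here. Compound 4 `O=C(/C=C/c1ccccc1OC(F)(F)F)c1ccc(O)cc1` is not yet measured in this assay; it differs from compound 3 by 4-hydroxyphenyl in place of 3-hydroxyphenyl on a carbonyl carbon, the same change as from compound 1 to compound 2. With the step that the two limits leave unreadable from compound 1 to compound 2 unreadable, only a small step is expected here: a 1.1-fold higher number from compound 3 to compound 4 (0.05 log units; within the scatter). Compound 4 is therefore estimated at 1800 nM, expected to fall between 600 nM and 6000 nM.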

Compound 4, half-maximal inhibitory concentration: 1340 nM
The estimate for compound 4 lay 1.3-fold (0.13 log units) above the measured number; the range from low to high includes it.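

In this assay, 4-hydroxyphenyl in place of 3-hydroxyphenyl on a carbonyl carbon gives a 1.2-fold lower number from compound 3 to compound 4 (0.08 log units; within the scatter), so on the core of compound 3 the two placements cannot be told apart. The same change on the core of compound 1 gives no readable step, because the values of compound 1 and compound 2 are limits of the assay and not numbers: the limit of > 10000 nM in this assay, at which 2 of the 4 values shown sit. The step on the core of compound 3 thus shows a small effect on that core alone and does not show that the change carries over from one core to another.

The compounds shown leave open what an amine or a carboxylic acid in place of the hydroxyl would give on the core of compound 3.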